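Swapping a hexyl chain for a hydroxylated alkyne

A few compounds are considered here, and "the series" means these few. Any claim that something is new, unique, unknown or untested is made for them only; others in the source may bear on it.

Two compounds share one core and differ only in the chain on one carbon of the ring. Compound 1 `CC#CCc1cn([C@H]2C[C@H](O)[C@@H](CO)O2)c(=O)[nH]c1=O` carries a prop-1-yn-1-yl chain; in a functional assay on L1210 cells (Mus musculus) (a higher number here means a weaker inhibitor, a lower number a stronger inhibitor), compound 1 gives only a limit of the assay, > 1000 ug/mL. Among the measured compounds shown here, compound 2 `CCCCCCc1cn([C@H]2C[C@H](O)[C@@H](CO)O2)c(=O)[nH]c1=O` carries a hexyl chain, and in this assay compound 2 gives 301 ug/mL, the only actual number among the values shown. That change gave an at least 3.3-fold lower number from compound 1 to compound 2 (0.52 log units; beyond the scatter). Compound 3 `O=c1[nH]c(=O)n([C@H]2C[C@H](O)[C@@H](CO)O2)cc1C#CCCCO` is not yet measured; the change is 5-hydroxypent-1-yn-1-yl in place of hexyl on an aromatic carbon, which brings back a triple bond outside aromatic rings and adds a hydrogen-bond donor. Compound 1 sits at the limit of > 1000 ug/mL in this assay, at which 1 of the 2 values shown sits, and is the one with the triple bond. The step of an at least 3.3-fold lower number from compound 1 to compound 2 (0.52 log units; beyond the scatter), which removed it, ran the other way. For compound 3 in this assay a rise beyond the scatter is therefore expected, estimated at 1000 ug/mL with a range from 300 ug/mL to 3000 ug/mL. This means an expected step of a 3.3-fold higher number from compound 2 to compound 3 (0.52 log units; beyond the scatter), and quite possibly only a limit will again be seen.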

Compound 3, concentration for 50% inhibition: 280 ug/mL
Beside the measured number, compound 3's estimate is 3.6-fold (0.55 log units) above it, and the stated range ends above it.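

In this assay the result is a 1.1-fold lower number from compound 2 to compound 3 (0.03 log units; within the scatter), so at this aromatic carbon the hexyl chain and the 5-hydroxypent-1-yn-1-yl chain cannot be told apart. A triple bond in the chain does not by itself keep a compound at the limit of the assay: the step between the two chains that carry one, from but-2-yn-1-yl to 5-hydroxypent-1-yn-1-yl, is an at least 3.5-fold lower number from compound 1 to compound 3 (0.55 log units; beyond the scatter). Compound 1 alone remains at a limit of the assay: the limit of > 1000 ug/mL in this assay, at which 1 of the 3 values shown sits.

Going by these compounds, compound 3 brings in the triple bond and the hydroxyl group together, so what each does alone remains open. A saturated pentyl chain ending in a hydroxyl group, a longer chain, or a chain ending in an amine or a carboxylic acid could show how much this position tolerates.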